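The source may report more compounds than this note shows. Statements on the series, on what has been measured and on what is new or still open speak of the compounds shown alone.

Working notes on the series. In a functional assay on HeLa cells (Homo sapiens) for antiproliferative activity, read by MTT assay, with a stated time of 48 h (a higher number here means a weaker inhibitor, a lower number a stronger inhibitor), compound 1 `CCN(CC)CCn1c(N)c(-c2nc3ccccc3n2C)c2nc(C#N)c(C#N)nc21` stands at a limit of the assay, > 50000 nM, and not at a number. Compound 2 `CN(C)CCCCn1c(N)c(-c2nc3ccccc3n2C)c2nc(C#N)c(C#N)nc21` reads 460 nM. For the measured compounds named here, the only measured step is an at least 100-fold lower number from compound 1 to compound 2 (2.03 log units; beyond the scatter), which is large and beyond the scatter. It lies on the saturated chain, however, and not at the place changed next.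

Compound 3 `CCN(CC)CCn1c(N)c(-c2nc3cc(Cl)ccc3[nH]2)c2nc(C#N)c(C#N)nc21` keeps the 2-(diethylamino)ethyl group of compound 1 and carries 5-chloro-1H-benzimidazol-2-yl in place of 1-methyl-1H-benzimidazol-2-yl on an aromatic carbon. Going by the values given here, no measured step covers this swap, so an at least 100-fold lower number from compound 1 to compound 2 (2.03 log units; beyond the scatter) shows only that one change can move a compound off the limit. A lower number in this assay is expected, but by less than that step, and a reading at the limit remains possible. The estimated step is an at least 6.2-fold lower number from compound 1 to compound 3 (0.79 log units; beyond the scatter). The expected value for compound 3 is 8000 nM, with an estimated range of 800 nM to 50000 nM.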

Compound 3, half-maximal inhibitory concentration: > 50000 nM
Compound 3 ended at the assay's limit (the forecaster's own chance of this, stated with the estimate: 30%); middle value at least 6.2-fold (0.79 log units) from the limit.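

No new step can be read between compound 1 and compound 3, because both stand at the same limit and not at a number: the limit of > 50000 nM in this assay, at which 2 of the 3 values shown sit.

The compounds shown leave open how far 5-chloro-1H-benzimidazol-2-yl in place of 1-methyl-1H-benzimidazol-2-yl moves the number in this assay, and in which direction.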